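Removing the ring hydroxy from compound 2

A few compounds are considered here, and "the series" means these few. Any claim that something is new, unique, unknown or untested is made for them only; others in the source may bear on it.

Measured so far in a functional assay on MIA PaCa-2 cells (Homo sapiens) for inhibition, read by MTT assay, with a stated time of 48 h, tested at 10 uM; on this read-out higher numbers stand for more inhibition of growth at the one concentration tested and lower numbers for less inhibition of growth
compound 1 `Cc1cc(=O)c2c(O)c(CN(C)CC(=O)O)c(O)c([C@H]3CCN(C)C[C@H]3O)c2o1` gives 16%
compound 2 `Cc1cc(=O)c2c(O)c(CN3CC(O)CC3C(=O)O)c(O)c([C@H]3CCN(C)C[C@H]3O)c2o1` gives 23%

Compound 2 at 23% lies within the scatter of compound 1, so the pair gives it no distinct place in this assay and no order can be read from these two numbers. The next structure is compound 3 `Cc1cc(=O)c2c(O)c(CN3CCCC3C(=O)O)c(O)c([C@H]3CCN(C)C[C@H]3O)c2o1`. Against compound 2 the change is hydrogen in place of hydroxy on a saturated ring carbon, in short hydrogen in place of hydroxy on a saturated ring carbon. For the measured compounds named here, no measured pair isolates this hydroxy group. Going by the values given here, the only step that bears on it is a number 7 percentage points higher from compound 1 to compound 2 (within the scatter), a change in the same amino part of the side chain, and it does not leave the scatter. On that basis no direction is favoured, and the expected step is a number 3 percentage points lower from compound 2 to compound 3 (within the scatter), with nothing expected beyond the scatter. For compound 3 the estimate is 20%, with an expected range from 8% to 33%.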

Compound 3, percent growth inhibition at one concentration: 10%
The estimate for compound 3 lay 10 percentage points above the measured number; low and high end bracket the measured number.
By their numbers in this assay, from the lowest: compounds 3, 1 and 2 (each within the scatter of the next, the first and the last beyond it).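

In this assay, for the compounds shown here, the hydroxy on the saturated ring carbon is the first single change to clear the scatter, with a number 13 percentage points lower from compound 2 to compound 3 (beyond the scatter), a modest step. Without that hydroxy, the 2-carboxypyrrolidin-1-yl group does not separate from the (carboxymethyl)(methyl)amino group, with a number 6 percentage points lower from compound 1 to compound 3 (within the scatter), so the only separation seen among these compounds depends on the hydroxy of compound 2. Nothing measured accounts for the step.

From the compounds shown here alone, whether an amine, a methoxy group or a fluorine atom on that ring carbon would read like the hydroxy or like hydrogen remains open. Also open, going by these compounds, is whether the hydroxy step would persist with a methyl ester or a primary amide in place of the carboxy group.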